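The source may hold more compounds than are shown below. What is called first, only, known or untested is meant among the compounds shown, and "the series" means these compounds.

Compounds measured in a functional assay on DU-145 cells (Homo sapiens) for inhibition, read by trypan blue exclusion, with a stated time of 96 h; a higher number here means a weaker inhibitor of growth, a lower number a stronger inhibitor of growth:

- Compound 1 `Cc1ccc(CS/C(=C/c2ccc(O)c(O)c2O)C(=O)c2ccc(Cl)cc2)cc1`: 50000 nM
- Compound 2 `Cc1ccc(S(=O)(=O)/C(=C/c2ccc(N(C)C)cc2)C(=O)c2ccc(Cl)cc2)cc1`: > 100000 nM, a limit of the assay
- Compound 3 `Cc1ccc(CS/C(=C/c2c[nH]c3ccc(Cl)cc23)C(=O)c2ccc(Cl)cc2)cc1`: 1000 nM

Of the two true numbers, compound 3 has the lower, 1000 nM. Among the measured compounds shown here, the only measured step, a 50-fold lower number from compound 1 to compound 3 (1.70 log units; beyond the scatter), is large, beyond the scatter, and lies at the same place as the change now in question. Compound 4 `Cc1ccc(CS/C(=C/c2ccc(N(C)C)cc2)C(=O)c2ccc(Cl)cc2)cc1` differs from compound 3 as follows: 4-(dimethylamino)phenyl in place of 5-chloro-1H-indol-3-yl on a double-bonded chain carbon bound to a double-bonded chain carbon. Compound 2 also carries the 4-(dimethylamino)phenyl group but differs elsewhere, and its > 100000 nM is a limit. Given a 50-fold lower number from compound 1 to compound 3 (1.70 log units; beyond the scatter), this place clearly can shift the number a long way, so a step to a higher number, beyond the scatter but probably smaller than that one, is expected in this assay. The expected change is a 10-fold higher number from compound 3 to compound 4 (1.00 log units; beyond the scatter). For compound 4 the estimated value is 10000 nM, with an expected range from 1500 nM to 60000 nM.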

Compound 4, concentration for 50% growth inhibition: > 100000 nM
Compound 4 ended at the assay's limit (the forecaster's own chance of this, stated with the estimate: 15%); middle value at least 10-fold (1.00 log units) from the limit.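

In this assay, putting 4-(dimethylamino)phenyl in place of 5-chloro-1H-indol-3-yl gives an at least 100-fold higher number from compound 3 to compound 4 (2.00 log units; beyond the scatter), so a change at this place can also push the number strongly upward. Set against 2,3,4-trihydroxyphenyl, the same group gives an at least 2.0-fold higher number from compound 1 to compound 4 (0.30 log units; that floor lies within the scatter), so this step is not shown to lie beyond the scatter, while 5-chloro-1H-indol-3-yl stands clearly apart from both other groups. The value of compound 4 is a limit, which makes both steps floors and leaves the steps between limits unreadable, including the one from compound 2: the limit of > 100000 nM in this assay, at which 2 of the 4 values shown sit.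

Going by these compounds, whether the low number of compound 3 depends on the chlorine or on the rest of 5-chloro-1H-indol-3-yl stays open. So does how a methoxyphenyl or pyridyl group would read at this place.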